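Shifting the Thiophene Attachment Point in Compound 1

This account rests on a few compounds, and the source may have more. Where it says the series, first, only, none or still open, it means among the compounds named here.

Compound 1 has the structure `Oc1ccc(-c2cc(-c3cccs3)cc(-c3ccccc3O)n2)cc1`. In a functional assay on DU-145 cells (Homo sapiens) for cytotoxicity, read by CCK-8 assay (on this read-out lower numbers stand for stronger inhibition and higher numbers for weaker inhibition), compound 1 gives > 50000 nM, which is a limit of the assay rather than a measured number. Compound 2, with the structure `Oc1ccc(-c2cc(-c3cccs3)cc(-c3ccc(O)cc3)n2)cc1`, gives 2190 nM in this assay. Among the measured compounds shown here, the only measured step, an at least 22-fold lower number from compound 1 to compound 2 (1.35 log units; beyond the scatter), concerns the hydroxyphenyl groups and leaves the thiophene untouched, and since compound 1 sits at the limit of > 50000 nM in this assay, at which 1 of the 2 values shown sits, only a bound is known on its side of that step. Compound 3, with the structure `Oc1ccc(-c2cc(-c3ccsc3)cc(-c3ccccc3O)n2)cc1`, keeps both hydroxyphenyl groups of compound 1 and changes only the thiophene: thiophen-3-yl in place of thiophen-2-yl on an aromatic carbon. For the measured compounds named here, no measured step touches a change of this kind, so in this assay there is no ground to expect a step beyond the scatter in either direction. Compound 3 is therefore expected to land close to compound 1, at 50000 nM, within a range from 15000 nM to 150000 nM, quite possibly again as a limit. This estimate for compound 3 means an expected step of a number no higher from compound 1 to compound 3 (the limit leaves the size open).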

Compound 3, half-maximal inhibitory concentration: > 50000 nM
Compound 3 was reported as a limit (the forecaster's own chance of this, stated with the estimate: 70%); the middle value lies on the limit itself.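

In this assay, no step can be read between compound 1 and compound 3, since both are reported only as a limit and not as a number: the limit of > 50000 nM in this assay, at which 2 of the 3 values shown sit.

The compounds shown leave open whether thiophen-3-yl in place of thiophen-2-yl changes anything in this assay, including on a compound with a measurable value, such as compound 2.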